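Swapping a long nitrile chain for cyclobutyl

A few compounds are considered here, and "the series" means these few. Any claim that something is new, unique, unknown or untested is made for them only; others in the source may bear on it.

- compound 1 `CN1C(=S)[C@@H](NC(=O)c2nc(Cc3ccccc3)n(CCC(F)(F)F)n2)COc2ccccc21`: > 100000 nM, a limit
- compound 2 `CN1C(=S)[C@@H](NC(=O)c2nc(Cc3ccccc3)n(CCCCCC#N)n2)COc2ccccc21`: > 100000 nM, a limit

In a toxicity assay on HT-29 cells (Homo sapiens) for cytotoxicity (a higher number here means that more compound is tolerated, a lower number that less compound is tolerated), compound 2 sits at a limit, > 100000 nM, and so has no exact number. Compound 3 `CN1C(=S)[C@@H](NC(=O)c2nc(Cc3ccccc3)n(C3CCC3)n2)COc2ccccc21` differs from compound 2 by cyclobutyl in place of 5-cyanopentyl on an aromatic nitrogen. Among the measured compounds shown here, the only measured step, a step that the two limits leave unreadable from compound 1 to compound 2, has no readable size, so it offers no size to carry over. The expectation therefore rests on (the limit of > 100000 nM in this assay, at which 2 of the 2 values shown sit). In this assay the estimated a number no higher from compound 2 to compound 3 (the limit leaves the size open) is expected to stay within the scatter, with no clear direction. Compound 3 is expected at about 100000 nM, with an estimated range of 30000 nM to 200000 nM.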

Compound 3, half-maximal cytotoxic concentration: > 100000 nM
Compound 3: only a limit was reported; the forecaster's own chance of this, stated with the estimate: 85%; the middle value sits exactly at the limit.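

In this assay, compound 3 sits at a limit, as do compound 1 and compound 2, so no step among these three compounds can be read. As far as these compounds go, whether the group on the aromatic nitrogen changes the tolerated concentration at all remains open.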